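This account rests on a few compounds, and the source may have more. Where it says the series, first, only, none or still open, it means among the compounds named here.

Working notes on a small set of selenium-bearing anilides and diselenides, all examined in an ADME assay on THP-1 cells (Homo sapiens) for cytotoxicity, with a stated time of 24 h; a higher number here means a weaker inhibitor, a lower number a stronger inhibitor. Compound 1 `O=C(NC(=[Se])Nc1ccc([Se][Se]c2ccc(NC(=[Se])NC(=O)c3ccco3)cc2)cc1)c1ccco1` gives 7440 nM, and compound 3 `O=C(NC(=[Se])Nc1ccc([Se][Se]c2ccc(NC(=[Se])NC(=O)c3cnc4ccccc4c3)cc2)cc1)c1cnc2ccccc2c1` gives 12800 nM. Compound 2 `N#C[Se]c1ccc(NC(=O)COCC(=O)O)cc1` is not pinned to a number: in this assay compound 2 reaches only > 25000 nM, which is a limit of the assay, not a value. Compound 2 thus stands at the limit of > 25000 nM in this assay, at which 1 of the 3 values shown sits. The change to compound 4 `N#C[Se]c1ccc(NC(=O)/C=C\C(=O)O)cc1` is 2-carboxyethenyl in place of (carboxymethoxy)methyl on a carbonyl carbon. For the measured compounds named here, no measured pair in this set differs in a single place, so no measured step sets the scale; with the rest of compound 2 kept, the expected step is a number no higher from compound 2 to compound 4 (the limit leaves the size open), nothing beyond the usual scatter. For compound 4 the estimate is 25000 nM, between 10000 nM and 60000 nM, and most likely again only a limit is expected.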

Compound 4, half-maximal inhibitory concentration: > 25000 nM
Compound 4: no number, only a limit (the forecaster's own chance of this, stated with the estimate: 70%); the middle value sits exactly at the limit.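

No step can be read between compound 2 and compound 4: each gives only a limit, not a number. The compounds shown leave open what 2-carboxyethenyl in place of (carboxymethoxy)methyl on a carbonyl carbon does to the read-out.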